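From benzyloxycarbonyl to (4-methylphenyl)sulfonyl on the shared core

The source may report more compounds than this note shows. Statements on the series, on what has been measured and on what is new or still open speak of the compounds shown alone.

Compound 1 `C=Cn1c2ccc([N+](=O)[O-])cc2c(=O)n1Cc1ccccc1`: 160000 nM
Compound 2 `O=C(OCc1ccccc1)n1c2ccc([N+](=O)[O-])cc2c(=O)n1Cc1ccccc1`: 86100 nM

Both values come from an ADME assay on L929 cells (Mus musculus) for cytotoxicity, read by resazurin assay, with a stated time of 48 h; on this read-out lower numbers stand for higher toxicity in this test and higher numbers for lower toxicity in this test. Among the compounds with values here, compound 2, at 86100 nM, lies within the scatter of compound 1, the only other measured compound. Compound 3 `Cc1ccc(S(=O)(=O)n2c3ccc([N+](=O)[O-])cc3c(=O)n2Cc2ccccc2)cc1` carries (4-methylphenyl)sulfonyl in place of benzyloxycarbonyl on an aromatic nitrogen. Within the data shown here, one measured step bears on this place: a 1.9-fold lower number from compound 1 to compound 2 (0.27 log units; within the scatter), which stayed within the scatter. No step beyond the scatter is therefore expected in this assay, in either direction. The estimated step is a 1.2-fold higher number from compound 2 to compound 3 (0.06 log units; within the scatter). For compound 3 the expected value is 100000 nM, with an estimated range from 45000 nM to 200000 nM.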

Compound 3, concentration lethal to 50% of the cells: > 256000 nM
Compound 3: a limit, no number (the forecaster's own chance of this, stated with the estimate: 8%); at least 2.5-fold (0.40 log units) between middle value and limit.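

In this assay compound 3 reaches a limit of the assay, not a number: the limit of > 256000 nM in this assay, at which 1 of the 3 values shown sits.

Within the data shown here, this gives the first reading beyond the scatter at this aromatic nitrogen: replacing benzyloxycarbonyl with (4-methylphenyl)sulfonyl gives an at least 2.9-fold higher number from compound 2 to compound 3 (0.47 log units; beyond the scatter), so the group here can matter to the read-out. Replacing vinyl with the same group gives an at least 1.6-fold higher number from compound 1 to compound 3 (0.20 log units; that floor lies within the scatter), so no order between those two compounds can be read.

As far as these compounds go, how far compound 3 lies past its limit stays open. So does what an amine or a carboxylic acid at this place would give in this assay.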